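The source may report more compounds than this note shows. Statements on the series, on what has been measured and on what is new or still open speak of the compounds shown alone.

Measured compounds:
- compound 2 `CCCCCCCC/C=C\c1c(C)c(/C=C\CCCCCCCC)c2[n+](c1C)CCC2` — 22.7 uM
- compound 3 `CCCCCCCCCCc1c(C)c(CCCCCCCCCC)c2[n+](c1C)CCC2` — 2.8 uM
- compound 1 `CCCCCCCC/C=C\c1c(C)cc(C)nc1CCCOC` — "not determined" (no result reported)

In an ADME assay on NIH3T3 cells (Mus musculus) for cytotoxicity, read by neutral red uptake, with a stated time of 48 h (on this read-out higher numbers stand for lower toxicity in this test and lower numbers for higher toxicity in this test), compound 2 gives 22.7 uM, the higher of the two numbers recorded. Compound 3 gives 2.8 uM in this assay, and the gap between compound 3 and compound 2 lies beyond the scatter of repeated measurements. For compound 1 no number was reported in this assay. Among the measured compounds shown here, no two measured compounds differ from each other in one place only, so no single isolated step is known for this series.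

Compound 4 `CCCCCCCC/C=C/c1c(C)c(/C=C/CCCCCCCC)c2[n+](c1C)CCC2` is the next entry. the two compounds have the same atoms and bonds and differ only in configuration as drawn: 2 of 2 stereo elements differ; a double bond is drawn Z in compound 2 and E in compound 4; a double bond is drawn Z in compound 2 and E in compound 4 Nothing leaves and nothing enters; the change from compound 2 to compound 4 is confined to the configuration drawn at the two double bonds, each going from Z to E.

For the measured compounds named here, with no measured step of this kind to lean on, a modest move is expected in this assay, toward a lower number, of roughly the size of the scatter or somewhat beyond it. Compound 4 is expected to give about 12 uM, with a range from 4 uM to 35 uM. The expected step is a 1.9-fold lower number from compound 2 to compound 4 (0.28 log units; within the scatter).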

Compound 4, half-maximal toxic concentration: 2.5 uM
Estimate against measurement, compound 4: 4.8-fold (0.68 log units) above, outside the stated range (below it).
By their numbers in this assay, from the lowest: compounds 4 and 3 (each within the scatter of the next); then compound 2.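

In this assay, the configuration of the two double bonds matters on its own, with a 9.1-fold lower number from compound 2 to compound 4 (0.96 log units; beyond the scatter), so within this pair the E,E form stands for higher toxicity in this test than the Z,Z form. Among the compounds shown here, the earlier compounds offered no pair differing in one place, so this is the first isolated step. Because nothing leaves and nothing enters, the step belongs to configuration alone and to no change in atoms: the fact that compounds 2 and 4 differ only in the configuration as drawn

On these data alone, both double bonds change together here, so the share of each one, and the behaviour of a form with one Z and one E double bond, stay open. Also open, as far as these compounds go, is whether the same configuration effect holds with a longer chain, or with a terminal amine or carboxylic acid on the side chains.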